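Amide Side-Chain Replacement on a Shared Core

The source may report more compounds than this note shows. Statements on the series, on what has been measured and on what is new or still open speak of the compounds shown alone.

The three compounds measured so far in a functional assay on MCF7 cells (Homo sapiens) for antiproliferative activity, read by MTT assay, with a stated time of 24 h; on this read-out lower numbers stand for stronger inhibition and higher numbers for weaker inhibition:

compound 1 `CCn1c(C(=O)N[C@@H](C)C(=O)OC)ccc1C(CC)(CC)c1ccc(OCS(=O)(=O)c2ccccc2)c(C)c1`: 43700 nM
compound 2 `CCn1c(C(=O)N[C@H](C)C(=O)OC)ccc1C(CC)(CC)c1ccc(OCS(=O)(=O)c2ccccc2)c(C)c1`: > 50000 nM
compound 3 `CCn1c(C(=O)N[C@@H](CO)CCO)ccc1C(CC)(CC)c1ccc(OCS(=O)(=O)c2ccccc2)c(C)c1`: 27400 nM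

The value of compound 2 is a limit of this assay and not a number, (the limit of > 50000 nM in this assay, at which 1 of the 3 values shown sits). Compounds 1 and 2 share all atoms and bonds, (the fact that compounds 1 and 2 differ only in the configuration as drawn), and give an at least 1.1-fold higher number from compound 1 to compound 2 (0.05 log units; that floor lies within the scatter). Among the two numbers, compound 3 stands lowest, with compound 1 nearest: a 1.6-fold lower number from compound 1 to compound 3 (0.20 log units; within the scatter). Compound 4 `CCn1c(C(=O)N[C@@H](CC(=O)O)C(=O)O)ccc1C(CC)(CC)c1ccc(OCS(=O)(=O)c2ccccc2)c(C)c1` differs from compound 3 in one place: 1,2-dicarboxyethyl in place of 3-hydroxy-1-(hydroxymethyl)propyl on an amide-type nitrogen. Within the data shown here, the steps that bear on this change are those at the same amide-type nitrogen, a 1.6-fold lower number from compound 1 to compound 3 (0.20 log units; within the scatter) and an at least 1.8-fold lower number from compound 2 to compound 3 (0.26 log units; that floor lies within the scatter), neither beyond the scatter. Compound 4 is therefore expected to show no step beyond the scatter in this assay, a 1.3-fold higher number from compound 3 to compound 4 (0.11 log units; within the scatter). The estimate for compound 4 is 35000 nM, between 15000 nM and 80000 nM.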

Compound 4, half-maximal inhibitory concentration: > 50000 nM
Compound 4: a limit, no number (the forecaster's own chance of this, stated with the estimate: 30%); middle value at least 1.4-fold (0.15 log units) from the limit.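

In this assay compound 4 gives > 50000 nM, which is a limit and not a number, and a second compound now sits there: the limit of > 50000 nM in this assay, at which 2 of the 4 values shown sit. With 1,2-dicarboxyethyl on the amide-type nitrogen, the two readable steps are floors, an at least 1.8-fold higher number from compound 3 to compound 4 (0.26 log units; that floor lies within the scatter) and an at least 1.1-fold higher number from compound 1 to compound 4 (0.05 log units; that floor lies within the scatter), so this change, like the earlier ones at this position, has shown no step beyond the scatter. The step between the two limits, compound 2 and compound 4, cannot be read.

On these data alone, how far compound 4 lies past its limit remains open. Also open, as far as these compounds go, is whether an amine or a longer chain on this nitrogen would give a step beyond the scatter.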